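This account rests on a few compounds, and the source may have more. Where it says the series, first, only, none or still open, it means among the compounds named here.

Among the compounds with values here, compound 3 `O=C1O[C@H]([C@@H](O)Cn2cc(CNS(=O)(=O)c3ccc(F)cc3)nn2)C(OCc2ccccc2)=C1OCc1ccccc1` is the one member of this small set that gives a number rather than a limit in a functional assay on MCF7 cells (Homo sapiens) for antiproliferative activity, read by MTT assay, with a stated time of 72 h; on this read-out lower numbers stand for stronger inhibition and higher numbers for weaker inhibition: compound 3 gives 26800 nM. Compound 1 `O=C1O/C(=C\Cn2cc(-c3cc(F)cc(F)c3)nn2)C(OCc2ccccc2)=C1OCc1ccccc1` in this assay gives > 100000 nM, which is a limit of the assay and not a number. Compound 2 `CCCCCc1ccc(-c2cn(C/C=C3\OC(=O)C(OCc4ccccc4)=C3OCc3ccccc3)nn2)cc1` in this assay likewise gives > 100000 nM, again a limit. Within the data shown here, the one single-point step among the measured compounds, a step that the two limits leave unreadable from compound 1 to compound 2, is therefore unreadable, since both ends sit at the limit of > 100000 nM in this assay, at which 2 of the 3 values shown sit.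

Compound 4 `COc1ccc(-c2cn(C[C@H](O)[C@H]3OC(=O)C(OCc4ccccc4)=C3OCc3ccccc3)nn2)cc1` differs from compound 3 in one place: 4-methoxyphenyl in place of (((4-fluorophenyl)sulfonyl)amino)methyl on an aromatic carbon. Among the measured compounds shown here, no measured step touches this change, so no size can be read from the data for it. What the set does show is that both compounds carrying an aryl group on the five-membered ring stay at the limit, while compound 3 alone is read. Compound 4 is expected to move toward that limit, with a step of a 2.2-fold higher number from compound 3 to compound 4 (0.35 log units; beyond the scatter), and its value is estimated at 60000 nM, within 20000 nM to 200000 nM.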

Compound 4, half-maximal inhibitory concentration: 99700 nM
Compound 4: middle estimate off by 1.7-fold (0.22 log units), on the low side, and the stated range covers the measured number.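

Within the data shown here, with a 3.7-fold higher number from compound 3 to compound 4 (0.57 log units; beyond the scatter) in this assay, this is the first change in the set whose size can be read, and it shows that the group on this aromatic carbon of the five-membered ring affects the read-out. Compound 4 carries an aryl group on that carbon and still gives a number, so the earlier pattern of aryl-bearing compounds sitting at the limit does not hold for every such compound. Compounds 1 and 2 remain limits and not numbers: the limit of > 100000 nM in this assay, at which 2 of the 4 values shown sit.

The change replaces the whole (((4-fluorophenyl)sulfonyl)amino)methyl group at once, so the step cannot be assigned to any one part of that group, such as its hydrogen-bond donor or its fluorine. From the compounds shown here alone, it also remains open where a smaller group on the same carbon, such as an aminomethyl group or a carboxylic acid, would fall relative to compound 3.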